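Replacing the benzoxazolylsulfanyl arm of compound 1 with methylpiperazine

The source may report more compounds than this note shows. Statements on the series, on what has been measured and on what is new or still open speak of the compounds shown alone.

Compound 1 `Cc1ccc2oc(SCC(=O)Nc3ccc(-c4nc(-c5ccccc5)c(-c5ccccc5)n4C)cc3)nc2c1` is one of three compounds sharing a core and differing only in the group carried at the end of the acetamide chain. In a functional assay on MCF7 cells (Homo sapiens) for cytotoxicity, read by MTT assay, with a stated time of 24 h, tested at 16 ug/mL (on this read-out higher numbers stand for a stronger effect at the one concentration tested and lower numbers for a weaker effect), compound 1 gives 40.3%, the lowest of the three numbers. Compound 2 `Cn1nnnc1SCC(=O)Nc1ccc(-c2nc(-c3ccccc3)c(-c3ccccc3)n2C)cc1` gives 63.7% and compound 3 `Cc1nnc(SCC(=O)Nc2ccc(-c3nc(-c4ccccc4)c(-c4ccccc4)n3C)cc2)s1` gives 74.9%. The measured steps are a number 23.4 percentage points higher from compound 1 to compound 2 (beyond the scatter), a number 34.6 percentage points higher from compound 1 to compound 3 (beyond the scatter) and a number 11.2 percentage points higher from compound 2 to compound 3 (beyond the scatter).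

Compound 4 `CN1CCN(CC(=O)Nc2ccc(-c3nc(-c4ccccc4)c(-c4ccccc4)n3C)cc2)CC1` has not yet been tested. Its difference from compound 1 is 4-methylpiperazin-1-yl in place of (5-methyl-1,3-benzoxazol-2-yl)sulfanyl on a saturated chain carbon bound to a carbonyl carbon. The two steps that start from compound 1 both remove the 5-methyl-1,3-benzoxazol-2-yl group and both go up, but each keeps the sulfur and brings in another five-membered aromatic ring, whereas compound 4 loses the sulfur as well and gains a non-aromatic ring. Among the compounds with values here, no measured step covers that change, so the expectation leans on the shared direction of the two steps from compound 1 while allowing a wide range. The author therefore expects a modest increase, a number 14.7 percentage points higher from compound 1 to compound 4 (beyond the scatter), and estimates that compound 4 will give 55%, between 30% and 80%.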

Compound 4, a percentage reported as activity, at one concentration (the size of the read-out at that concentration, not a potency): 30.1%
Estimate against measurement, compound 4: 24.9 percentage points above; the measured number falls inside the stated range.
By their numbers in this assay, from the lowest: compound 4; then compound 1; then compound 2; then compound 3.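

In this assay, 4-methylpiperazin-1-yl on a saturated chain carbon bound to a carbonyl carbon gives the first downward step from compound 1, a number 10.2 percentage points lower from compound 1 to compound 4 (beyond the scatter), and the drop is larger from the two sulfur-linked compounds that scored higher, a number 44.8 percentage points lower from compound 3 to compound 4 (beyond the scatter) and a number 33.6 percentage points lower from compound 2 to compound 4 (beyond the scatter). Compound 4 therefore goes against the rise seen in compound 2 and compound 3, and it is the weakest of the four, so the gain from leaving the benzoxazole behind does not hold for this change, which also gives up the sulfur and the aromatic rings. No measurement is available that would explain this drop.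

Because sulfur and ring change together in compound 4, the compounds shown cannot say which of the two matters. As far as these compounds go, it also remains open how a morpholin-4-yl group, an open-chain dimethylamino group or a piperazine attached through sulfur would behave at this place.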